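The compounds below may be only part of what the source reports. "The series", "measured", "known", "first", "only" and "open" are said of these compounds alone.

Measured compounds:
compound 1 `O=C(Nc1ccccc1O)C1CCc2ccccc2N1C(=O)c1ccccc1Cl` — 60000 nM
compound 2 `O=C(Nc1ccccc1O)C1CCc2ccccc2N1C(=O)c1ccc(Cl)cc1` — 25100 nM
compound 3 `O=C(Nc1ccccc1C(F)(F)F)C1CCc2ccccc2N1C(=O)c1ccc(Cl)cc1` — 786 nM

In a functional assay on PC-3 cells (Homo sapiens) for cytotoxicity, read by sulforhodamine B assay, with a stated time of 72 h (a higher number here means a weaker inhibitor of growth, a lower number a stronger inhibitor of growth), compound 2 holds the second highest of the three numbers. Among the compounds with values here, the two measured steps are a 2.4-fold lower number from compound 1 to compound 2 (0.38 log units; beyond the scatter) and a 32-fold lower number from compound 2 to compound 3 (1.50 log units; beyond the scatter), the first a swap of one chlorophenyl for another on the carbonyl carbon, the second an exchange of hydroxy for trifluoromethyl on the aromatic carbon of the other side.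

Compound 4 `CCCCCCCCC(=O)N1c2ccccc2CCC1C(=O)Nc1ccccc1O` differs from compound 2 by octyl in place of 4-chlorophenyl on a carbonyl carbon. Within the data shown here, neither measured step bears on this change; no step replaces an aromatic group with a chain on that carbonyl carbon, so the direction of the effect is not predictable from these data. No step beyond the scatter is assumed, with a wide range to either side. Compound 4 is expected at 25000 nM, with a range of 7000 nM to 90000 nM. The step expected is a 1.0-fold lower number from compound 2 to compound 4 (0.00 log units; within the scatter).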

Compound 4, concentration for 50% growth inhibition: 45200 nM
Beside the measured number, compound 4's estimate is 1.8-fold (0.26 log units) below it, within the range that was stated.
By their numbers in this assay, from the lowest: compound 3; then compounds 2, 4 and 1 (each within the scatter of the next, the first and the last beyond it).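

In this assay, a ring-free octyl on this carbonyl carbon, with hydroxy kept on the other side, gives a 1.8-fold higher number from compound 2 to compound 4 (0.26 log units; within the scatter) and a 1.3-fold lower number from compound 1 to compound 4 (0.12 log units; within the scatter) and so cannot be told apart from either chlorophenyl group. At this position, and at this weak level of growth inhibition, the aromatic ring can therefore be exchanged for a chain without a step beyond the scatter. No available measurement accounts for this result.

Open, on these data alone, is whether octyl holds this level with trifluoromethyl in place of hydroxy, as in compound 3. Also open, as far as these compounds go, is how a shorter chain, or a chain ending in an amine or a carboxylic acid, would read here.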